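Methyl for Hydrogen on the Carboxymethyl Chain

The compounds below may be only part of what the source reports. "The series", "measured", "known", "first", "only" and "open" are said of these compounds alone.

Measured compounds:
compound 1 `CC1=CCC[C@H]2[C@](C)(CC3=CC(=O)C=C(N[C@@H](C(=O)O)C(C)C)C3=O)[C@@H](C)CC[C@]12C`: 7780 nM
compound 2 `CC1=CCC[C@H]2[C@](C)(CC3=CC(=O)C=C(NCCC(=O)O)C3=O)[C@@H](C)CC[C@]12C`: 15500 nM
compound 3 `CC1=CCC[C@H]2[C@](C)(CC3=CC(=O)C=C(NCC(=O)O)C3=O)[C@@H](C)CC[C@]12C`: 15600 nM

All three share one core and were tested in a functional assay on K562 cells (Homo sapiens) for cytotoxicity, read by MTT assay, with a stated time of 72 h; on this read-out lower numbers stand for stronger inhibition and higher numbers for weaker inhibition. Among the compounds with values here, compound 3 has the highest number of the three, yet its steps to compound 2 and to compound 1 both lie within the scatter, so no compound can be called stronger or weaker than another. Compound 4 `CC1=CCC[C@H]2[C@](C)(CC3=CC(=O)C=C(N[C@@H](C)C(=O)O)C3=O)[C@@H](C)CC[C@]12C` differs from compound 3 by methyl in place of hydrogen on a saturated chain carbon bound to an amine nitrogen and a carbonyl carbon. Within the data shown here, the one measured step at this same place is a 2.0-fold higher number from compound 1 to compound 3 (0.30 log units; within the scatter); the neighbouring change on the chain, a 1.0-fold higher number from compound 2 to compound 3 (0.00 log units; within the scatter), was likewise flat. Because a 2.0-fold higher number from compound 1 to compound 3 (0.30 log units; within the scatter) stayed within the scatter, compound 4 is expected near 11000 nM, between 5500 nM and 22000 nM. That expected step, a 1.4-fold lower number from compound 3 to compound 4 (0.15 log units; within the scatter), is within the scatter.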

Compound 4, half-maximal inhibitory concentration: 15800 nM
For compound 4 the middle estimate is 1.4-fold (0.16 log units) below the measured one, and the stated range covers the measured number.
By their numbers in this assay, from the lowest: compounds 1, 2, 3 and 4 (each within the scatter of the next, the first and the last beyond it).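

On a saturated chain carbon bound to an amine nitrogen and a carbonyl carbon, methyl in place of hydrogen leaves the number in this assay within the scatter (a 1.0-fold higher number from compound 3 to compound 4 (0.01 log units; within the scatter)). The 1-carboxyethyl and 2-carboxyethyl chains cannot be told apart either (a 1.0-fold higher number from compound 2 to compound 4 (0.01 log units; within the scatter)). Only 1-carboxyethyl in place of 1-carboxy-2-methylpropyl lies beyond the scatter, and modestly so (a 2.0-fold higher number from compound 1 to compound 4 (0.31 log units; beyond the scatter)), although compound 3, with hydrogen at this place, stays within the scatter of compound 1. As far as these compounds go, what a benzyl group on this carbon, or an amide in place of the carboxylic acid, would give remains open. Nothing available explains these numbers.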